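Phenyl for Methyl on the Amide Chain of Compound 1

The source may report more compounds than this note shows. Statements on the series, on what has been measured and on what is new or still open speak of the compounds shown alone.

Measured compounds:
Compound 1, `CCCCNC(=O)C1C(C(=O)O)[C@@H]2CC[C@H]1O2`: 10000 nM
Compound 2, `CCc1ccccc1NC(=O)C1C(C(=O)O)[C@@H]2CC[C@H]1O2`: 10000 nM
Compound 3, `CCOC(=O)c1cn[nH]c1NC(=O)C1C(C(=O)O)[C@@H]2CC[C@H]1O2`: 10000 nM

All three share one core, carrying an acid and an amide. In an ADME assay on DU-145 cells (Homo sapiens) for cytotoxicity, read by MTT assay, with a stated time of 72 h (on this read-out higher numbers stand for weaker inhibition of growth and lower numbers for stronger inhibition of growth), compound 1 gives 10000 nM. Compound 2 gives 10000 nM and compound 3 gives 10000 nM in this assay. Compound 1 therefore stands level with both, and as the three values sit within the usual scatter of one another, no order among them can be drawn.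

Compound 4, `O=C(O)C1C(C(=O)NCCCc2ccccc2)[C@H]2CC[C@@H]1O2`, differs from compound 1 by phenyl in place of methyl on a saturated chain carbon, three bonds along the chain from an amide-type nitrogen. For the measured compounds named here, no pair of measured compounds shows this change, so nothing here points to a step in either direction in this assay; none beyond the scatter is expected. Compound 4 is expected to give 10000 nM, between 5000 nM and 20000 nM, a step of no change at the digits printed from compound 1 to compound 4 (within the scatter).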

Compound 4, concentration for 50% growth inhibition: 10000 nM
Beside the measured number, compound 4's estimate shows no gap at the digits printed, within the range that was stated.
By their numbers in this assay, from the lowest: compounds 1, 2, 3 and 4 (each within the scatter of the next).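

Phenyl in place of methyl on a saturated chain carbon, three bonds along the chain from an amide-type nitrogen, is the first change in one place that can be read here, and in this assay it gives no change at the digits printed from compound 1 to compound 4 (within the scatter) as its step. At this position, then, a six-membered aromatic ring leaves the growth read-out unmoved. Nothing measured offers a reason for this result.

Still open, from the compounds shown here alone, is whether an amine or a carboxylic acid at this place on the chain, or a longer chain, would shift the value.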